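The source may hold more compounds than are shown below. What is called first, only, known or untested is meant among the compounds shown, and "the series" means these compounds.

In a functional assay on HeLa cells (Homo sapiens) for inhibition, read by sulforhodamine B assay, with a stated time of 74 h (a lower number here means a stronger inhibitor, a higher number a weaker inhibitor), three compounds sharing one core have been measured. Compound 1 `CS(=O)(=O)N1C(=O)COC12C=CC(=O)C=C2`, with methyl on the sulfonyl sulfur, gives 7530 nM. Compound 2 `O=C1C=CC2(C=C1)OCC(=O)N2S(=O)(=O)c1ccccc1`, with phenyl in that place, reads > 10000 nM, which is a limit of the assay and not a number. Compound 3 `Cc1ccccc1S(=O)(=O)N1C(=O)COC12C=CC(=O)C=C2`, with 2-methylphenyl there, gives 3720 nM, making it the strongest inhibitor of the three.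

Compound 4 `O=C1C=CC2(C=C1)OCC(=O)N2S(=O)(=O)c1cccs1` has thiophen-2-yl in place of 2-methylphenyl on a sulfonyl sulfur. For the measured compounds named here, two measured steps bear on this change. Adding the methyl to the phenyl ring gave an at least 2.6-fold lower number from compound 2 to compound 3 (0.42 log units; beyond the scatter), while replacing that substituted ring with methyl gave a 2.0-fold lower number from compound 1 to compound 3 (0.31 log units; beyond the scatter). Both are modest, and the ring in compound 4 carries no such methyl. The gain seen in an at least 2.6-fold lower number from compound 2 to compound 3 (0.42 log units; beyond the scatter) is therefore expected to be lost, with the number moving upward. The expected change is a 2.2-fold higher number from compound 3 to compound 4 (0.33 log units; beyond the scatter), a modest weakening. Compound 4 is estimated at 8000 nM, within an expected range of 3500 nM to 15000 nM.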

Compound 4, half-maximal inhibitory concentration: 3420 nM
Estimate against measurement, compound 4: 2.3-fold (0.37 log units) above, outside the stated range (below it).
By their numbers in this assay, from the lowest: compounds 4 and 3 (each within the scatter of the next); then compound 1. At a limit, above all of these: compound 2.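

Compound 4 carries no methyl on its ring, yet the change to thiophen-2-yl gives a 1.1-fold lower number from compound 3 to compound 4 (0.04 log units; within the scatter) in this assay, so on this sulfonyl sulfur a ring without that methyl can match the 2-methylphenyl of compound 3. The identity of the unsubstituted ring also counts here, as thiophen-2-yl in place of phenyl gives an at least 2.9-fold lower number from compound 2 to compound 4 (0.46 log units; beyond the scatter) and this step is only a floor. Against the small methyl group, the thiophen-2-yl ring gives a 2.2-fold lower number from compound 1 to compound 4 (0.34 log units; beyond the scatter), which places it with 2-methylphenyl, though the shift is modest.

On these data alone, what a furan ring or an amine on the sulfonyl sulfur would give remains open. As far as these compounds go, how far compound 2 truly lies from the others also remains open, as its value is a limit and not a number: the limit of > 10000 nM in this assay, at which 1 of the 4 values shown sits.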